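Replacing the Dihalogenated Anilide with a Pyridinyl Amide

The compounds below may be only part of what the source reports. "The series", "measured", "known", "first", "only" and "open" are said of these compounds alone.

Compound 3 `COc1ccc(C(=O)Nc2c(F)cccc2Cl)cc1OC1CCCC1` stands second highest of the three numbers in an assay on isolated protein for inhibition of phosphodiesterase 4A (Sus scrofa) (a higher number here means a weaker inhibitor, a lower number a stronger inhibitor), at 240 nM. Compound 2 `COc1ccc(C(=O)Nc2c(F)cccc2F)cc1OC1CCCC1` gives 70 nM, and compound 1 `COc1ccc(C(=O)Nc2ccccc2F)cc1OC1CCCC1` gives 10700 nM. The measured steps show how much the two halogens on the anilide ring matter: a 150-fold lower number from compound 1 to compound 2 (2.18 log units; beyond the scatter) and a 45-fold lower number from compound 1 to compound 3 (1.65 log units; beyond the scatter), while a 3.4-fold higher number from compound 2 to compound 3 (0.54 log units; beyond the scatter). Compound 4 `COc1ccc(C(=O)Nc2cccnc2)cc1OC1CCCC1` differs from compound 3 in one place: pyridin-3-yl in place of 2-chloro-6-fluorophenyl on an amide-type nitrogen. Among the compounds with values here, this removes both the fluoro and the chloro, running against the large gains seen from compound 1 to compounds 2 and 3, and no measured compound carries a nitrogen-containing ring. The expected outcome is therefore a large upward step, a 42-fold higher number from compound 3 to compound 4 (1.62 log units; beyond the scatter). Compound 4 is estimated at 10000 nM, with a range from 2000 nM to 50000 nM.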

Compound 4, half-maximal inhibitory concentration: 550 nM
The estimate for compound 4 lay 18-fold (1.26 log units) above the measured number; measured number below the stated range.
By their numbers in this assay, from the lowest: compound 2; then compound 3; then compound 4; then compound 1.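

Pyridin-3-yl carries neither fluoro nor chloro, yet replacing the dihalogenated rings with it raises the number only modestly (a 2.3-fold higher number from compound 3 to compound 4 (0.36 log units; beyond the scatter)) and (a 7.9-fold higher number from compound 2 to compound 4 (0.90 log units; beyond the scatter)). Against the 2-fluorophenyl group, the same ring brings a large gain (a 19-fold lower number from compound 1 to compound 4 (1.29 log units; beyond the scatter)). A second halogen is therefore not the only route to a low number at this amide-type nitrogen. The compounds shown offer no evidence on what lies behind this result. From the compounds shown here alone, whether pyridin-4-yl, or a pyridin-3-yl ring bearing an added fluoro or amine, would match compound 4 remains open.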